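The source may hold more compounds than are shown below. What is called first, only, known or untested is meant among the compounds shown, and "the series" means these compounds.

In an ADME assay on Vero cells (Chlorocebus sabaeus) for cytotoxicity, read by MTT assay, with a stated time of 72 h (on this read-out higher numbers stand for lower toxicity in this test and lower numbers for higher toxicity in this test), compound 1 (`Cc1ccc(C(=O)N2CCN(c3nc(=O)c4cc(C(F)(F)F)cc([N+](=O)[O-])c4s3)CC2)cc1`) gives > 125000 nM as its reading, which is a limit and not a number. Compound 2 (`CC1COC2(CCN(c3nc(=O)c4cc(C(F)(F)F)cc([N+](=O)[O-])c4s3)CC2)O1`) gives > 125000 nM as its reading, again a limit. Compound 3 (`CC(C)(C)C(=O)N1CCN(c2nc(=O)c3cc(C(F)(F)F)cc([N+](=O)[O-])c3s2)CC1`) gives > 125000 nM as its reading, also a limit. Compound 1 therefore has no exact value to stand on, and the picture so far is the limit of > 125000 nM in this assay, at which 3 of the 3 values shown sit, in every case.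

Compound 4 (`O=C(c1cccc(F)c1)N1CCN(c2nc(=O)c3cc(C(F)(F)F)cc([N+](=O)[O-])c3s2)CC1`) has 3-fluorophenyl in place of 4-methylphenyl on a carbonyl carbon and is otherwise the same as compound 1. Within the data shown here, the one measured step at this carbonyl carbon, with tert-butyl in place of 4-methylphenyl, is a step that the two limits leave unreadable from compound 1 to compound 3 and offers no size to carry over. Nothing measured points to a direction, so no change beyond the scatter is expected in this assay for this replacement, and the expectation rests on compound 1 and compound 3 both reaching the same limit. The estimated step is a step that the limit leaves unreadable from compound 1 to compound 4 and it is expected to stay within the scatter. The estimate for compound 4 is 130000 nM as a value, with an expected range from 60000 nM to 250000 nM and a good chance of only a limit again.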

Compound 4, half-maximal cytotoxic concentration: > 125000 nM
Compound 4 gave a limit, no number (the forecaster's own chance of this, stated with the estimate: 85%); the middle value is on the limit's open side.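

In this assay compound 4 gives > 125000 nM, which is a limit and not a number, so neither its step from compound 1 nor its step from compound 3 can be read. All the readings share one limit: the limit of > 125000 nM in this assay, at which 4 of the 4 values shown sit.

The compounds shown leave open where any of them would give an exact half-maximal cytotoxic concentration, and whether the groups on the carbonyl carbon differ at all.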